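Lengthening the side chain toward a carboxylic acid

The compounds below may be only part of what the source reports. "The series", "measured", "known", "first", "only" and "open" are said of these compounds alone.

Three measured compounds share one core and differ only in the chain on a saturated carbon bound to an aromatic carbon. In an assay on COS-7 cells for displacement of a labelled ligand from Endothelin receptor type B (Sus scrofa) (a lower number here means a stronger inhibitor, a higher number a weaker inhibitor), compound 1 `COc1cccc(Sc2c(NS(=O)(=O)c3ccc(C(C)(C)C)cc3)noc2CCCCC=O)c1` gives 20 nM. Compound 2 `COc1cccc(Sc2c(NS(=O)(=O)c3ccc(C(C)(C)C)cc3)noc2CCO)c1` gives 430 nM, and compound 3 `COc1cccc(Sc2c(NS(=O)(=O)c3ccc(C(C)(C)C)cc3)noc2CO)c1` gives 560 nM, the highest number of the three; its nearest neighbour is compound 2 and its furthest is compound 1. The steps tell the story: a 22-fold higher number from compound 1 to compound 2 (1.33 log units; beyond the scatter) and a 28-fold higher number from compound 1 to compound 3 (1.45 log units; beyond the scatter) are both large, while a 1.3-fold higher number from compound 2 to compound 3 (0.11 log units; within the scatter) lies within the scatter. A longer chain ending in a carbonyl thus goes with a much lower number than a short chain ending in hydroxy. Compound 4 `COc1cccc(Sc2c(NS(=O)(=O)c3ccc(C(C)(C)C)cc3)noc2CCCC(=O)O)c1` makes the change (2-carboxyethyl in place of hydroxy on a saturated chain carbon bound to an aromatic carbon). A large step downward is expected, a 14-fold lower number from compound 3 to compound 4 (1.15 log units; beyond the scatter), because a 28-fold higher number from compound 1 to compound 3 (1.45 log units; beyond the scatter) shows how strongly the longer chain lowers the number, though a carboxylic acid end rather than an aldehyde end leaves room for the value not to fall all the way. Compound 4 is therefore estimated at 40 nM, with a range from 10 nM to 160 nM.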

Compound 4, half-maximal inhibitory concentration: 500 nM
Compound 4: middle estimate off by 13-fold (1.10 log units), on the low side, outside the stated range (above it).
By their numbers in this assay, from the lowest: compound 1; then compounds 2, 4 and 3 (each within the scatter of the next).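

In this assay, a longer chain ending in a carboxylic acid does not bring back the low number of compound 1: a 25-fold higher number from compound 1 to compound 4 (1.40 log units; beyond the scatter) is large, while a 1.1-fold lower number from compound 3 to compound 4 (0.05 log units; within the scatter) and a 1.2-fold higher number from compound 2 to compound 4 (0.07 log units; within the scatter) both lie within the scatter. Chain length alone therefore does not go with a low number at this position, since the chains ending in hydroxy or carboxy sit together and only the aldehyde-ended chain of compound 1 stands apart. Nothing available here explains why these chain ends differ so much.

Compound 1 differs from compound 4 in both the end of the chain and its length, so the two cannot be separated here. Going by these compounds, whether a carboxylic acid on a longer chain, an aldehyde on a shorter chain, or an ester or amide end would give a low number remains open.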